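Chloro for Trifluoromethyl on a Shared Core

The source may hold more compounds than are shown below. What is called first, only, known or untested is meant among the compounds shown, and "the series" means these compounds.

The measured compounds are:
compound 1 `CNc1ccc(Sc2ccc([N+](=O)[O-])cc2)c(C(=O)Nc2ccccc2OC)c1`, in an ADME assay on H9 cells (Homo sapiens) for cytotoxicity, read by MTT assay, with a stated time of 7 days (a higher number here means that more compound is tolerated, a lower number that less compound is tolerated), compound 1 gives 302000 nM
compound 2 `COc1ccccc1NC(=O)c1cc(NC(C)=O)ccc1Sc1ccc([N+](=O)[O-])cc1`, in this assay compound 2 gives 171000 nM
compound 3 `COc1ccccc1NC(=O)c1cc(C(F)(F)F)ccc1Sc1ccc([N+](=O)[O-])cc1`, for which this assay reports "not determined" (no result reported)

Compound 3 therefore has no number in this assay on which to stand, and only compounds 1 and 2 give a sense of where this series sits. Among the measured compounds shown here, the one measured step, a 1.8-fold lower number from compound 1 to compound 2 (0.25 log units; within the scatter), concerns a different position from the one that now changes, and it stays within the scatter.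

Compound 4 `COc1ccccc1NC(=O)c1cc(Cl)ccc1Sc1ccc([N+](=O)[O-])cc1` differs from compound 3 by the change (chloro in place of trifluoromethyl on an aromatic carbon). For the measured compounds named here, no measured pair bears directly on this change, and no step to compound 4 can be computed since compound 3 has no value. Going by the values given here, what can be said is that the two measured members, compound 1 and compound 2, fall close to one another in this assay, with nothing in the data pointing to a move beyond the scatter for any single change on the shared core.

On that basis compound 4 is expected to give about 200000 nM in this assay, with a range from 60000 nM to 500000 nM.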

Compound 4, half-maximal cytotoxic concentration: 483000 nM
Compound 4: middle estimate off by 2.4-fold (0.38 log units), on the low side, and the stated range covers the measured number.
By their numbers in this assay, from the lowest: compounds 2, 1 and 4 (each within the scatter of the next, the first and the last beyond it).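

Among the compounds shown here, at the position para to a (4-nitrophenyl)sulfanyl group, the swap of acetamido for chloro gives the first step in this assay that lies beyond the scatter, a 2.8-fold higher number from compound 2 to compound 4 (0.45 log units; beyond the scatter). Chloro in place of methylamino, by contrast, gives a 1.6-fold higher number from compound 1 to compound 4 (0.20 log units; within the scatter), so among the three compounds with numbers, this position shows a clear difference only between the chloro and acetamido groups, while compound 1 stays within the scatter of both. The exchange of trifluoromethyl for chloro itself cannot be read, and nothing at hand explains the size of either step.

On these data alone, it stays open whether trifluoromethyl, with its four heavy atoms against the single one of chloro, would stand near compound 4 or apart from it in this assay. Also open, as far as these compounds go, is how other groups at this aromatic carbon, such as bromo, a nitrile, a carboxylic acid or an unsubstituted amine, would compare, and so whether the gap between chloro and acetamido reflects anything wider than this one pair.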